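Phenyl in Place of Bromo: Two Measured, One Expected

The compounds below may be only part of what the source reports. "The series", "measured", "known", "first", "only" and "open" are said of these compounds alone.

Compound 2 `CC(=O)c1ccc(Nc2ccnc(SCC(=O)c3ccc(Br)cc3)n2)cc1` stands lowest of the two numbers in a functional assay on PC-3 cells (Homo sapiens) for inhibition, read by sulforhodamine B assay, with a stated time of 48 h, tested at 10 uM (on this read-out lower numbers stand for less inhibition of growth and higher numbers for more inhibition of growth at the one concentration tested), where compound 2 gives 25%; compound 1 `CC(=O)c1cccc(Nc2ccnc(SCC(=O)c3ccc(C(F)(F)F)cc3)n2)c1` gives 30% in this assay, a number within the scatter of that of compound 2. Compound 3 `CC(=O)c1ccc(Nc2ccnc(SCC(=O)c3ccc(-c4ccccc4)cc3)n2)cc1` differs from compound 2 by phenyl in place of bromo on an aromatic carbon. Among the measured compounds shown here, no step between measured compounds exists to guide this change. The step of a number 10 percentage points higher from compound 2 to compound 3 (within the scatter) is expected to be small, likely not beyond the scatter. Compound 3 is expected to reach 35%, within 15% to 55%.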

Compound 3, percent growth inhibition at one concentration: 19%
Estimate against measurement, compound 3: 16 percentage points above; the range from low to high includes it.
By their numbers in this assay, from the lowest: compounds 3, 2 and 1 (each within the scatter of the next, the first and the last beyond it).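

Phenyl in place of bromo, on an aromatic carbon para to a large group, gives in this assay a number 6 percentage points lower from compound 2 to compound 3 (within the scatter), the first step read at this position. A single bromine can thus give way to a six-membered aromatic ring of carbon only, with the step staying within the scatter. Nothing at hand explains this result. Still open, on these data alone, is whether an amine or a carboxylic acid on this carbon would move the number beyond the scatter.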